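The source may hold more compounds than are shown below. What is called first, only, known or untested is meant among the compounds shown, and "the series" means these compounds.

Of the compounds shown here, three sharing one core have been measured in an assay on isolated protein for binding affinity to Adrenergic receptor alpha-1 (Rattus norvegicus), read by radioligand binding, in the presence of a further agent that is not named here; a lower number here means a stronger inhibitor, a higher number a weaker inhibitor. Compound 1, `C1=NCC(CC2=Cc3ccccc3CC2)N1`, gives 398 nM. Compound 2, `FC(F)(F)c1ccc2c(c1)C=C(CC1CN=CN1)CC2`, carries a trifluoromethyl on an aromatic carbon in place of a hydrogen and gives 1260 nM; the step of a 3.2-fold higher number from compound 1 to compound 2 (0.50 log units; beyond the scatter) is modest but beyond the scatter. Compound 3, `Cc1ccc2c(c1)C=C(CC1CN=CN1)CC2`, carries a methyl on that aromatic carbon instead and gives 398 nM, so that no change at the digits printed from compound 1 to compound 3 (within the scatter), while a 3.2-fold lower number from compound 2 to compound 3 (0.50 log units; beyond the scatter). Compound 3 thus stands level with compound 1, the two together being the lowest numbers of the three, with compound 2 furthest away.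

Compound 4, `Cc1ccc2c(c1)C=C(CC1CN=C(N)O1)CC2`, keeps the methyl of compound 3 and changes the other end of the molecule: a group of 6 heavy atoms (3 carbon, 2 nitrogen, 1 oxygen; one five-membered non-aromatic ring with 2 hetero atoms) in place of a group of 5 heavy atoms (3 carbon, 2 nitrogen; one five-membered non-aromatic ring with 2 hetero atoms), on a saturated chain carbon bound to a double-bonded ring carbon. Within the data shown here, none of the three measured steps touches this part of the molecule; they all concern the aromatic substituent, and so there is no measured precedent here for the size or direction of the effect. Without such a precedent, the expectation rests on the shared core and the unchanged methyl alone. A modest weakening is expected, a 2.5-fold higher number from compound 3 to compound 4 (0.40 log units; beyond the scatter), with wide uncertainty. For compound 4 the expected value in this assay is 1000 nM, with a range from 250 nM to 4000 nM.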

Compound 4, inhibition constant: 251 nM
Estimate against measurement, compound 4: 4.0-fold (0.60 log units) above; the measured number falls inside the stated range.
By their numbers in this assay, from the lowest: compounds 4, 1 and 3 (each within the scatter of the next); then compound 2.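

Among these compounds, this is the first measured step at this end of the molecule, on a saturated chain carbon bound to a double-bonded ring carbon, and in this assay it reads a 1.6-fold lower number from compound 3 to compound 4 (0.20 log units; within the scatter). Among the compounds shown here, with the methyl on the aromatic carbon held fixed, the group of 6 heavy atoms, which adds an oxygen and counts 3 hydrogen-bond acceptors rather than 2, can therefore take the place of the group of 5 heavy atoms with no difference that stands clear of the scatter, whereas the earlier steps concerned only the aromatic substituent. Nothing measured here accounts for this result.

Going by these compounds, it remains open whether the same exchange would read alike with hydrogen or trifluoromethyl on the aromatic carbon in place of the methyl, given that the step from methyl to trifluoromethyl was beyond the scatter in the group of 5 heavy atoms. On these data alone, it is also open what a simple amine, a carboxylic acid or a longer chain would give at this place on the saturated chain carbon.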